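Aryl urea variation in the shared-core series

This account rests on a few compounds, and the source may have more. Where it says the series, first, only, none or still open, it means among the compounds named here.

Measured compounds in a functional assay on HepG2 cells (Homo sapiens) for antiproliferative activity, read by MTT assay, with a stated time of 48 h; on this read-out higher numbers stand for weaker inhibition and lower numbers for stronger inhibition:
compound 1 `COc1ccccc1NC(=O)Nc1cccc(CNc2nccnc2Cl)c1`: compound 1 gives 13700 nM
compound 2 `O=C(Nc1cccc(CNc2nccnc2Cl)c1)Nc1ccc(Cl)cc1Cl`: compound 2 gives 7230 nM

For the measured compounds named here, compound 2 stands at the lowest of the two numbers, with compound 1 nearest; the only measured step, a 1.9-fold lower number from compound 1 to compound 2 (0.28 log units; within the scatter), lies within the scatter. Compound 3 `O=C(Nc1cccc(CNc2nccnc2Cl)c1)Nc1ccccc1Cl` differs from compound 2 by hydrogen in place of chloro on an aromatic carbon. Going by the values given here, no measured step isolates this change; the available step a 1.9-fold lower number from compound 1 to compound 2 (0.28 log units; within the scatter) alters the same aryl group and stayed within the scatter, so no step beyond the scatter is expected here either. Compound 3 is expected to give 9500 nM, within 4000 nM to 22000 nM. The expected step is a 1.3-fold higher number from compound 2 to compound 3 (0.12 log units; within the scatter).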

Compound 3, half-maximal inhibitory concentration: 8560 nM
The estimate for compound 3 lay 1.1-fold (0.05 log units) above the measured number; measured number inside the range.
By their numbers in this assay, from the lowest: compounds 2, 3 and 1 (each within the scatter of the next).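

In this assay, hydrogen in place of chloro on the aromatic carbon para to a large group stays within the scatter (a 1.2-fold higher number from compound 2 to compound 3 (0.07 log units; within the scatter)), so 2-chlorophenyl and 2,4-dichlorophenyl do not separate on this read-out. Chloro in place of methoxy on an aromatic carbon also stays within the scatter (a 1.6-fold lower number from compound 1 to compound 3 (0.20 log units; within the scatter)), so this single exchange does not separate compound 1 and compound 3 either. No measured evidence bears on these results.

All steps shown lie within the scatter, so it remains open whether any change on this aryl group can move the number beyond it. As far as these compounds go, what an amine or a carboxylic acid would give on this ring also remains open.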